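Cyclopentyl to cyclohexyl esters on two thiophene cores

This account rests on a few compounds, and the source may have more. Where it says the series, first, only, none or still open, it means among the compounds named here.

Measured compounds in an assay on membranes from CHO cells for displacement of a labelled ligand from adenosine receptor A1 (Homo sapiens), read by scintillation counting, with a stated time of 60 min, tested at 1 uM; a lower number here means less inhibition, a higher number more inhibition at the concentration tested (going by the name of the read-out):
compound 1 `CC1=C(C(=O)OC2CCCC2)C(c2cccs2)NC(=O)N1` gives 9%
compound 2 `CC1=C(C(=O)OC2CCCCC2)C(c2cccs2)NC(=O)N1` gives 7%
compound 3 `CC1=C(C(=O)OC2CCCC2)C(c2ccsc2)NC(=O)N1` gives 5%

Going by the values given here, all three measured compounds sit at low inhibition in this assay, and no compound can be called stronger or weaker than another, since every difference among them lies within the usual scatter.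

Compound 1 and compound 2 differ by cyclohexyl in place of cyclopentyl on an oxygen next to a carbonyl group. The step was a number 2 percentage points lower from compound 1 to compound 2 (within the scatter), so the larger ester showed no effect that can be separated from noise.

Compound 1 and compound 3 carry different cores: thiophen-3-yl in place of thiophen-2-yl on a saturated ring carbon. The step was a number 4 percentage points lower from compound 1 to compound 3 (within the scatter), again within the scatter.

Compound 4 `CC1=C(C(=O)OC2CCCCC2)C(c2ccsc2)NC(=O)N1` has not yet been measured in this assay. It relates to compound 3 as compound 2 relates to compound 1: cyclohexyl in place of cyclopentyl on an oxygen next to a carbonyl group. The place of the change is described in the same words in both pairs, so this is the same change, made a second time, now on the core of compound 3. Because the earlier instance gave a number 2 percentage points lower from compound 1 to compound 2 (within the scatter), the step from compound 3 to compound 4 is expected to be equally small, a number 1 percentage points lower from compound 3 to compound 4 (within the scatter). Compound 4 is therefore estimated at 4%, with a range from 0% to 14%, resting on the value of compound 3 and the flat earlier step.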

Compound 4, a percentage reported as inhibition, at one concentration (the size of the read-out at that concentration, not a potency): 8%
Beside the measured number, compound 4's estimate is 4 percentage points below it; low and high end bracket the measured number.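

In this assay, cyclohexyl in place of cyclopentyl on an oxygen next to a carbonyl group gave a number 3 percentage points higher from compound 3 to compound 4 (within the scatter), and set beside the same change on the core of compound 1, it shows no dependence on the core that can be told from noise: the same change on two cores in this assay, a number 2 percentage points lower (within the scatter) from compound 1 to compound 2 and a number 3 percentage points higher (within the scatter) from compound 3 to compound 4, 5 percentage points apart, within the scatter of two such steps

Thiophen-3-yl in place of thiophen-2-yl on a saturated ring carbon gave a number 1 percentage points higher from compound 2 to compound 4 (within the scatter), and this change likewise reads alike with either ester: the same change on two cores in this assay, a number 4 percentage points lower (within the scatter) from compound 1 to compound 3 and a number 1 percentage points higher (within the scatter) from compound 2 to compound 4, 5 percentage points apart, within the scatter of two such steps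

Going by these compounds alone, these comparisons show only that neither change moves the read-out beyond the scatter in this set, so the agreement is between steps that are all indistinguishable from noise; they do not show that a change with a real effect would carry from one core to the other, since all four compounds sit at low inhibition and no such effect is present to be carried.

The compounds shown leave open whether any change at the ester can lift inhibition clear of the scatter, for instance a longer chain or an amine in place of the cycloalkyl ring. They also leave open whether a phenyl ring or a carboxylic acid on the saturated ring carbon, in place of the thiophene, would give a step large enough to test transfer between cores.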